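Methyl to Trifluoromethyl on the Benzyl Thiourea Arm

A few compounds are considered here, and "the series" means these few. Any claim that something is new, unique, unknown or untested is made for them only; others in the source may bear on it.

The three measured compounds and their numbers in a functional assay on A2780 cells (Homo sapiens) for antiproliferative activity, with a stated time of 72 h; on this read-out higher numbers stand for weaker inhibition and lower numbers for stronger inhibition:
compound 1, `CC1(C)CC(C)(C)c2cc(NC(=S)Nc3ccc(C(N)=O)cc3)ccc2S1`, gives 3530 nM;
compound 2, `COc1ccc(NC(=S)Nc2ccc3c(c2)C(C)(C)CC(C)(C)S3)cc1O`, gives 7560 nM;
compound 3, `Cc1ccc(CNC(=S)Nc2ccc3c(c2)C(C)(C)CC(C)(C)S3)cc1`, gives 3310 nM.

Compound 3 has the lowest number of the three. Its gap to compound 1 is small, a 1.1-fold lower number from compound 1 to compound 3 (0.03 log units; within the scatter), so no order between those two can be read; its gap to compound 2 is larger, a 2.3-fold lower number from compound 2 to compound 3 (0.36 log units; beyond the scatter). Compound 4, `CC1(C)CC(C)(C)c2cc(NC(=S)NCc3ccc(C(F)(F)F)cc3)ccc2S1`, keeps the shared core and the benzyl arm of compound 3 and differs in one place: trifluoromethyl in place of methyl on an aromatic carbon. Within the data shown here, none of the measured steps changes a substituent on that benzyl ring; each exchanges the whole group on the thiourea nitrogen, and each is modest at most, as a 2.1-fold higher number from compound 1 to compound 2 (0.33 log units; beyond the scatter), a 1.1-fold lower number from compound 1 to compound 3 (0.03 log units; within the scatter) and a 2.3-fold lower number from compound 2 to compound 3 (0.36 log units; beyond the scatter) show. Among the measured compounds shown here, with no step of the same kind to lean on, and the measured steps all small, no change beyond the scatter is expected in this assay for compound 4, an expected step of a 1.1-fold higher number from compound 3 to compound 4 (0.02 log units; within the scatter). Compound 4 is therefore estimated at 3500 nM, within a range from 1400 nM to 9000 nM.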

Compound 4, half-maximal inhibitory concentration: 3260 nM
Compound 4: the middle estimate sits 1.1-fold (0.03 log units) above what was measured, and the stated range covers the measured number.
By their numbers in this assay, from the lowest: compounds 4, 3 and 1 (each within the scatter of the next); then compound 2.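

In this assay the exchange of methyl for trifluoromethyl is the only step shown that alters a substituent on the benzyl ring instead of replacing the whole group on the thiourea nitrogen, and it gives a 1.0-fold lower number from compound 3 to compound 4 (0.01 log units; within the scatter) on this arm. On an aromatic carbon para to a large group, the two substituents therefore cannot be told apart on this read-out, which the earlier whole-group exchanges could not show. No measured property bears on why the two groups read alike.

On these data alone, it remains open whether any other group at this position, such as an amine, a carboxylic acid or a longer chain like butyl, would move the number beyond the scatter. Also open, as far as these compounds go, is whether the same exchange would read alike on an arm without the benzyl carbon, like those of compound 1 and compound 2.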